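The compounds below may be only part of what the source reports. "The series", "measured", "known", "first", "only" and "open" are said of these compounds alone.

Compound 2 `CCOC(=O)/C=C/c1ccc(NC(=O)C2(NC(=O)c3ccc4c(C5CCCC5)c(-c5ncc(Cl)cn5)n(C)c4c3)CCC2)cc1OCC` is the ethyl ester of this series, and in an ADME assay (liver) for pharmacokinetics, with Liver microsome (Rattus norvegicus) as the target, using microsomes (on this read-out lower numbers stand for a shorter-lived compound and higher numbers for a longer-lived compound), compound 2 gives 3.07 h. For the measured compounds named here, this is the highest of the three numbers measured so far. Compound 1 `CCOc1cc(NC(=O)C2(NC(=O)c3ccc4c(C5CCCC5)c(-c5ncc(Cl)cn5)n(C)c4c3)CCC2)ccc1/C=C/C(=O)OCOP(=O)(O)O` gives 0.15 h, and compound 3 `CCOc1cc(NC(=O)C2(NC(=O)c3ccc4c(C5CCCC5)c(-c5ncc(Cl)cn5)n(C)c4c3)CCC2)ccc1/C=C/C(=O)OCCOCCOC` gives 1.07 h, so both sit below compound 2, with a 2.9-fold lower number from compound 2 to compound 3 (0.46 log units; beyond the scatter) and a 20-fold higher number from compound 1 to compound 2 (1.31 log units; beyond the scatter).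

Compound 4 `CCOc1cc(NC(=O)C2(NC(=O)c3ccc4c(C5CCCC5)c(-c5ncc(Cl)cn5)n(C)c4c3)CCC2)ccc1/C=C/C(=O)OCC(=O)OCc1ccc(Cl)cc1` differs from compound 2 only at the ester: ((4-chlorobenzyl)oxy)carbonyl in place of methyl on a saturated chain carbon bound to an oxygen next to a carbonyl group. Going by the values given here, the step that bears most directly on this is the one from compound 2 to compound 3, where a larger group was placed on the saturated chain carbon of the ester and the number fell, a 2.9-fold lower number from compound 2 to compound 3 (0.46 log units; beyond the scatter). The step from compound 1 to compound 2 also shows that what sits on this carbon can move the read-out a great deal, a 20-fold higher number from compound 1 to compound 2 (1.31 log units; beyond the scatter). Neither step tests the same group as compound 4, but both point the same way: enlarging the ester beyond ethyl has so far given a lower number.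

Compound 4 is therefore expected to show a modest step downward from compound 2, a 3.8-fold lower number from compound 2 to compound 4 (0.58 log units; beyond the scatter). The estimate for compound 4 in this assay is 0.8 h, with a range from 0.3 h to 2 h.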

Compound 4, half-life: 11.4 h
Estimate against measurement, compound 4: 14-fold (1.15 log units) below, and the stated range ends below it.
By their numbers in this assay, from the lowest: compound 1; then compound 3; then compound 2; then compound 4.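

In this assay, enlarging the group on the saturated chain carbon bound to an oxygen next to a carbonyl group does not in itself lower the number: ((4-chlorobenzyl)oxy)carbonyl in place of methyl gives a 3.7-fold higher number from compound 2 to compound 4 (0.57 log units; beyond the scatter), the opposite direction to the earlier 2-methoxyethoxy change. The comparison of the two larger groups, an 11-fold higher number from compound 3 to compound 4 (1.03 log units; beyond the scatter), shows that the identity of the group at this place, and not only its size, sets the direction of the change. With a 76-fold higher number from compound 1 to compound 4 (1.88 log units; beyond the scatter), the four compounds show a wide spread from changes at this one place, but they follow no simple order by size. Compound 3 goes against any rise with size. It stands below compound 2 although it carries the larger group. Nothing in the data presented explains why the number rises with the new group.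

As far as these compounds go, it remains open whether the higher number belongs to the chlorine, the aromatic ring or the added carbonyl, which a plain benzyl ester or a carboxylic acid at this place could help to separate. From the compounds shown here alone, it also remains open whether the same order of the compounds would hold with a longer chain between the ester oxygen and the added carbonyl.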